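Methyl removal on the fluorophenyl ring: compound 2 to compound 3

This account rests on a few compounds, and the source may have more. Where it says the series, first, only, none or still open, it means among the compounds named here.

Measured compounds:
- Compound 1 `COc1ccc(C2=C(c3cc(OC)c(OC)c(OC)c3)CC3CCCN3C2=O)cc1O`. In a functional assay on A498 cells (Homo sapiens) for cytotoxicity (on this read-out lower numbers stand for stronger inhibition of growth and higher numbers for weaker inhibition of growth), compound 1 gives only a limit, > 100000 nM.
- Compound 2 `CSc1ccc(C2=C(c3ccc(F)c(C)c3)C(=O)N3CCCC3C2)cc1`. In this assay compound 2 gives 300 nM.

Among the measured compounds shown here, compound 2 holds the only numerical value in this assay; the other entry is the limit of > 100000 nM in this assay, at which 1 of the 2 values shown sits, so no measured step bears on the change considered here.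

Compound 3 `CSc1ccc(C2=C(c3ccc(F)cc3)C(=O)N3CCCC3C2)cc1` differs from compound 2 by hydrogen in place of methyl on an aromatic carbon, at an aromatic carbon of a six-membered aromatic ring of carbon only, ortho to a fluoro group and meta to a large group.

Without any measured step of this kind in this assay, the expectation rests on the small size of the change: loss of a single carbon is expected to shift the value little, at most modestly toward weaker inhibition. The step of a 1.7-fold higher number from compound 2 to compound 3 (0.22 log units; within the scatter) is the estimated outcome. Compound 3 is expected to give about 500 nM in this assay, within 150 nM to 2000 nM.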

Compound 3, concentration for 50% growth inhibition: 100 nM
Estimate against measurement, compound 3: 5.0-fold (0.70 log units) above, outside the stated range (below it).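

In this assay, among the compounds shown here, the change from 4-fluoro-3-methylphenyl to 4-fluorophenyl gives the first readable step: a 3.0-fold lower number from compound 2 to compound 3 (0.48 log units; beyond the scatter). The methyl ortho to a fluoro group is therefore not needed for growth inhibition in this pair, and hydrogen at that aromatic carbon gives the stronger inhibition. Nothing measured here accounts for the size or direction of this step.

On these data alone, only methyl and hydrogen can be compared at this carbon, so the outcome with a longer chain such as ethyl, an amine or a carboxylic acid remains open. As far as these compounds go, compound 1 gives only a limit, > 100000 nM, and differs from compound 2 in more than one place, so whether the step carries over to other substitution on the shared core also remains open.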